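Swapping the thiazole aryl group in a benzofuran acid series

The source may report more compounds than this note shows. Statements on the series, on what has been measured and on what is new or still open speak of the compounds shown alone.

Compound 1, `Cc1nc(-c2cc3ccccc3o2)sc1COc1ccc2c(c1)OCC2CC(=O)O`: "not determined" (no result reported)
Compound 2, `Cc1nc(-c2cccc(Cl)c2)sc1COc1ccc2c(c1)OCC2CC(=O)O`: 138 nM
Compound 3, `Cc1nc(-c2ccccc2F)sc1COc1ccc2c(c1)OCC2CC(=O)O`: "not determined" (no result reported)

Compound 1 carries a 1-benzofuran-2-yl group on the thiazole of the shared core. In a functional assay on CHO cells for agonist activity at Free fatty acid receptor 1 (Homo sapiens), read by FLIPR and calcium flux (a higher number here means that more compound is needed for the effect, a lower number that less compound is needed), compound 1 stands at "not determined" (no result reported), and compound 3 likewise stands at "not determined" (no result reported). Only compound 2 offers a value, at 138 nM, so compound 1 cannot be placed above or below any other entry on the numbers at hand.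

Compound 4, `COc1ccc(-c2nc(C)c(COc3ccc4c(c3)OCC4CC(=O)O)s2)cc1`, differs from compound 1 in one place: 4-methoxyphenyl in place of 1-benzofuran-2-yl on an aromatic carbon. Because compound 1 has no measured value, the size of this step cannot be read from the data. Against the single number from compound 2, compound 4 is expected to fall within the scatter, with no clear direction.

Compound 4 is estimated to give 150 nM in this assay, within a range of 40 nM to 600 nM.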

Compound 4, half-maximal effective concentration: 123 nM
Compound 4: middle estimate off by 1.2-fold (0.09 log units), on the high side; the measured number falls inside the stated range.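

In this assay, putting 4-methoxyphenyl in place of 3-chlorophenyl gives a 1.1-fold lower number from compound 2 to compound 4 (0.05 log units; within the scatter), so the two groups cannot be told apart at this position. Within the data shown here, this is the first comparison here with a number at both ends, and it shows that, for this one pair, changing both the substituent and where it sits on the phenyl ring leaves the result within the scatter. No accompanying data bear on this result.

The step from compound 1 to compound 4 cannot be read, so the 1-benzofuran-2-yl and 2-fluorophenyl groups remain unplaced against the other two. Also open, as far as these compounds go, is how a non-aromatic group such as cyclohexyl, or a phenyl ring carrying a dimethylamino group, would read at this position.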